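Benzofuran series: carbonyl replaced by methylene on ring nitrogen

The source may report more compounds than this note shows. Statements on the series, on what has been measured and on what is new or still open speak of the compounds shown alone.

Measured so far in an assay on membranes from Cortex for displacement of a labelled ligand from Sigma non-opioid intracellular receptor 1 (Cavia porcellus), read by scintillation counting, with a stated time of 120 min; a higher number here means a weaker inhibitor, a lower number a stronger inhibitor:
compound 1 `Fc1ccc(C(SCCNC2CCN(Cc3ccccc3)CC2)c2ccc(F)cc2)cc1`: 3.81 nM
compound 2 `Fc1ccc(CN2CCC(NCCSC(c3ccc(F)cc3)c3ccc(F)cc3)CC2)cc1`: 13.3 nM
compound 3 `O=C(c1cc2ccccc2o1)N1CCC(NCCSC(c2ccc(F)cc2)c2ccc(F)cc2)CC1`: 304 nM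

Compound 3 stands highest of the three numbers in this assay; the nearest measured compound is reached by the step of a 23-fold higher number from compound 2 to compound 3 (1.36 log units; beyond the scatter), the furthest by an 80-fold higher number from compound 1 to compound 3 (1.90 log units; beyond the scatter). Both steps put the (1-benzofuran-2-yl)carbonyl group on the ring nitrogen in place of a benzyl-type group, and both are large and beyond the scatter.

Compound 4 `Fc1ccc(C(SCCNC2CCN(Cc3cc4ccccc4o3)CC2)c2ccc(F)cc2)cc1` is not yet measured. Its difference from compound 3 is (1-benzofuran-2-yl)methyl in place of (1-benzofuran-2-yl)carbonyl on an amine nitrogen in a ring. This change undoes the carbonyl that the steps from compound 1 and compound 2 to compound 3 introduced, while keeping the benzofuran. The step of a 3.5-fold higher number from compound 1 to compound 2 (0.54 log units; beyond the scatter) concerns the fluoro and does not bear here.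

The two large steps to compound 3 are taken as the guide, so compound 4 is expected to fall back toward the numbers of compound 1 and compound 2: an estimated step of a 38-fold lower number from compound 3 to compound 4 (1.58 log units; beyond the scatter), a lower number in this assay. For compound 4 the estimate is 8 nM, with a range from 2 nM to 40 nM.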

Compound 4, inhibition constant: 205 nM
The estimate for compound 4 lay 26-fold (1.41 log units) below the measured number; measured number above the stated range.
By their numbers in this assay, from the lowest: compound 1; then compound 2; then compounds 4 and 3 (each within the scatter of the next).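

In this assay, (1-benzofuran-2-yl)methyl in place of (1-benzofuran-2-yl)carbonyl on the ring nitrogen gives a 1.5-fold lower number from compound 3 to compound 4 (0.17 log units; within the scatter), so the carbonyl does not by itself separate compound 3 from compound 1 and compound 2. With the methylene link kept, 1-benzofuran-2-yl in place of the aryl ring gives a 15-fold higher number from compound 2 to compound 4 (1.19 log units; beyond the scatter) and a 54-fold higher number from compound 1 to compound 4 (1.73 log units; beyond the scatter), so among these four compounds the large steps go with the benzofuran and not with the carbonyl. Nothing available here explains this difference.

Open, on these data alone, is whether a benzoyl group on the ring nitrogen would stay near compound 1 and compound 2 or near compound 3. Also open, as far as these compounds go, is whether a furan-2-ylmethyl or naphthalen-2-ylmethyl group on that nitrogen would give numbers like those of compound 4.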